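A few compounds are considered here, and "the series" means these few. Any claim that something is new, unique, unknown or untested is made for them only; others in the source may bear on it.

Measured so far in an ADME assay on Caco-2 cells (Homo sapiens) for permeability, read by LC-MS, in the apical to basolateral direction, with a stated time of 60 min, at pH 6.5; on this read-out lower numbers stand for lower permeability and higher numbers for higher permeability:

- compound 1 `CC(C)(C)[C@@H](O)C(=O)N1CCS[C@H]1C(=O)NCc1cc(Cl)ccc1-n1cnnn1` gives 5.2 10^-6 cm/s
- compound 2 `Cc1cccc([C@@H](O)C(=O)N2N=CC[C@H]2C(=O)NCc2cc(Cl)ccc2-n2cnnn2)c1` gives 9.7 10^-6 cm/s

The values of compound 1 and compound 2 lie within the usual scatter of each other, so compound 2 stands level with compound 1 on these numbers. Going by the values given here, these two compounds differ in more than one place, and they offer no single-place step to serve as a guide.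

Compound 3 `O=C(NCc1cc(Cl)ccc1-n1cnnn1)[C@@H]1CC=NN1C(=O)[C@H](O)c1ccccc1F` has not yet been measured. It carries 2-fluorophenyl in place of 3-methylphenyl on a saturated chain carbon bound to a carbonyl carbon and an oxygen on a saturated carbon.

Among the compounds with values here, with no precedent for this swap, no change beyond the scatter is expected in this assay, and the estimated step is small: a 1.2-fold lower number from compound 2 to compound 3 (0.08 log units; within the scatter) (an expectation anchored only on compound 2 at 9.7 10^-6 cm/s). For compound 3 the estimated value is 8 10^-6 cm/s, with an expected range of 3.5 10^-6 cm/s to 16 10^-6 cm/s, as the reading still to come will test.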

Compound 3, apparent permeability: 8.9 10^-6 cm/s
Compound 3: middle estimate off by 1.1-fold (0.05 log units), on the low side; low and high end bracket the measured number.
By their numbers in this assay, from the lowest: compounds 1, 3 and 2 (each within the scatter of the next).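

In this assay, 2-fluorophenyl in place of 3-methylphenyl on a saturated chain carbon bound to a carbonyl carbon and an oxygen on a saturated carbon gives a 1.1-fold lower number from compound 2 to compound 3 (0.04 log units; within the scatter), a step within the usual scatter. This is the first single-place comparison among the compounds shown, and it indicates that this one exchange between two substituted phenyl groups, each of the same heavy-atom count, leaves the permeability read-out level. No measurement shown bears on why the two compounds stand level.

As far as these compounds go, only these two substituted phenyl groups can be compared at this position, so whether an amine, a carboxylic acid or a longer chain there would also leave the read-out level remains open. Compound 1 differs from compound 2 and compound 3 in more than one place, so it cannot settle that question.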